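Amino for hydroxy on the anilino ring: weak cytotoxicity expected

The compounds below may be only part of what the source reports. "The series", "measured", "known", "first", "only" and "open" are said of these compounds alone.

compound 1 `Fc1cccc(Nc2nc(-c3cccc(F)c3)nc3ccc(F)cc23)c1` — 47600 nM
compound 2 `Fc1cccc(-c2nc(Nc3ccccc3Cl)c3cc(F)ccc3n2)c1` — > 50000 nM
compound 3 `Oc1ccc(Nc2nc(-c3cccc(F)c3)nc3ccc(F)cc23)cc1` — > 50000 nM

Three compounds built on one shared core were tested in a functional assay on MDA-MB-231 cells (Homo sapiens) for cytotoxicity, read by MTT assay, with a stated time of 48 h; on this read-out lower numbers stand for stronger inhibition and higher numbers for weaker inhibition. Compound 1 gives 47600 nM. For compound 2 the value > 50000 nM is only a limit of the assay. For compound 3 the value > 50000 nM is likewise only a limit, so compound 3 stands at the edge of what this assay can read. This is the limit of > 50000 nM in this assay, at which 2 of the 3 values shown sit. Compound 4 `Nc1cccc(Nc2nc(-c3cccc(F)c3)nc3ccc(F)cc23)c1` differs from compound 3 by 3-aminophenyl in place of 4-hydroxyphenyl on a nitrogen on an aromatic ring. The measured steps that bear on this change are those made at the same position on the core: an at least 1.0-fold higher number from compound 1 to compound 2 (0.02 log units; that floor lies within the scatter) and an at least 1.0-fold higher number from compound 1 to compound 3 (0.02 log units; that floor lies within the scatter), while a step that the two limits leave unreadable from compound 2 to compound 3. Going by the values given here, all three values sit in the weak range and no step is readable beyond the scatter, so in this assay little movement is expected: the estimated step is a number no higher from compound 3 to compound 4 (the limit leaves the size open). Compound 4 is expected at 50000 nM, within 20000 nM to 120000 nM, and it is likely that this assay again reports only a limit.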

Compound 4, half-maximal inhibitory concentration: > 50000 nM
Compound 4 ended at the assay's limit; the forecaster's own chance of this, stated with the estimate: 60%; the middle value lies on the limit itself.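

In this assay compound 4 gives > 50000 nM, which is only a limit, so 3-aminophenyl, like 4-hydroxyphenyl and 2-chlorophenyl before it, yields no number at this position. Going by these compounds alone, the only readable step is the change of fluoro to amino on an aromatic carbon, an at least 1.0-fold higher number from compound 1 to compound 4 (0.02 log units; that floor lies within the scatter), while the steps among the compounds at the limit cannot be read. The new group therefore adds a third substituent on this nitrogen with no measurable value, and the position remains capped by the assay: the limit of > 50000 nM in this assay, at which 3 of the 4 values shown sit.

Going by these compounds, how far apart the compounds at the limit truly lie remains open. So does whether a different group on this nitrogen, such as a carboxylic acid or a longer chain ending in an amine, would give a value clear of the limit.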